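Replacing morpholin-4-yl with an aromatic amine on the amide

The compounds below may be only part of what the source reports. "The series", "measured", "known", "first", "only" and "open" are said of these compounds alone.

compound 1 `CCCN(CCC)C(=O)Cn1c(-c2ccc(Cl)cc2)nc2cccnc21`: 11 mg/kg
compound 2 `O=C(Cn1c(-c2ccc(Cl)cc2)nc2cccnc21)N1CCOCC1`: 11.5 mg/kg

In a functional assay on the whole organism with Mus musculus as the target (on this read-out lower numbers stand for an effect already at smaller amounts and higher numbers for an effect only at larger amounts of compound), compound 2 gives 11.5 mg/kg, and this lies within the scatter of the value for compound 1. The next structure is compound 3 `O=C(Cn1c(-c2ccc(Cl)cc2)nc2cccnc21)Nc1ccccn1`, with (pyridin-2-yl)amino in place of morpholin-4-yl on a carbonyl carbon. Within the data shown here, the only measured step at this place is a 1.0-fold higher number from compound 1 to compound 2 (0.02 log units; within the scatter). It involves no aromatic ring, so it offers only weak guidance here. On that basis, no change beyond the scatter is expected, and the estimated step is a 1.0-fold higher number from compound 2 to compound 3 (0.02 log units; within the scatter). Compound 3 is estimated at 12 mg/kg, with an expected range of 4 mg/kg to 35 mg/kg.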

Compound 3, dose for half-maximal effect: 100 mg/kg
Compound 3: middle estimate off by 8.3-fold (0.92 log units), on the low side, and the stated range ends below it.
By their numbers in this assay, from the lowest: compounds 1 and 2 (each within the scatter of the next); then compound 3.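

In this assay, the group on the carbonyl carbon proves able to shift the number: the change to (pyridin-2-yl)amino brings an 8.7-fold higher number from compound 2 to compound 3 (0.94 log units; beyond the scatter) and also a 9.1-fold higher number from compound 1 to compound 3 (0.96 log units; beyond the scatter) in the comparison with dipropylamino. This group brings both an aromatic ring and a hydrogen-bond donor, which neither earlier group has. Nothing measured here accounts for the step.

Which of these two features goes with the higher number remains open. A cyclohexylamino or a phenylamino group on the same carbonyl carbon would separate them.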